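This account rests on a few compounds, and the source may have more. Where it says the series, first, only, none or still open, it means among the compounds named here.

Among the compounds with values here, compound 1 `O/N=C(/CSc1nnc(-c2ccccc2)n1-c1ccccc1)c1ccccc1` sits second highest of the three numbers known in a functional assay on the whole organism (strain albino) for inhibition, with Rattus norvegicus as the target, read by paw edema, with a stated time of 3 h, at a dose of 0.28 mmol/kg by the oral route; on this read-out higher numbers stand for more inhibition at the one dose given (going by the name of the read-out) and lower numbers for less inhibition: compound 1 gives 65%. Compound 2 `COc1ccc(-c2nnc(SC/C(=N/O)c3ccccc3)n2-c2ccccc2)cc1OC` gives 67%, and compound 3 `O=C(CSc1nnc(-c2ccccc2)n1-c1ccccc1)c1ccccc1` gives 64%. The two measured steps were a number 2 percentage points higher from compound 1 to compound 2 (within the scatter), with 3,4-dimethoxyphenyl in place of phenyl on an aromatic carbon, and a number 1 percentage points lower from compound 1 to compound 3 (within the scatter). Compound 4 `CCn1c(SC/C(=N/O)c2ccccc2)nnc1-c1ccccc1` differs from compound 1 by ethyl in place of phenyl on an aromatic nitrogen. Neither measured step touches the aromatic nitrogen, so neither bears directly on this change; both were small. For compound 4 the expected value is therefore near that of compound 1, with a wider uncertainty. Compound 4 is expected to give 60%, between 45% and 75%. The step this estimate means is expected to be a number 5 percentage points lower from compound 1 to compound 4 (within the scatter).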

Compound 4, a percentage reported as inhibition, in the whole organism at one dose (the size of the read-out at that dose, not a potency): 72%
For compound 4 the middle estimate is 12 percentage points below the measured one, within the range that was stated.
By their numbers in this assay, from the lowest: compounds 3, 1, 2 and 4 (each within the scatter of the next).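

On the aromatic nitrogen of the shared core, ethyl in place of phenyl gives a number 7 percentage points higher from compound 1 to compound 4 (within the scatter) in this assay. The aromatic ring at this position can therefore be exchanged for a small chain with no ring, and the inhibition stays within the usual scatter. Nothing shown offers a reason for this result.

Still open, on these data alone, is whether a longer chain, such as butyl, or a chain carrying an amine or a carboxylic acid would hold the inhibition on this nitrogen. Also open, as far as these compounds go, is whether ethyl behaves the same way with 3,4-dimethoxyphenyl on the aromatic carbon.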